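The source may report more compounds than this note shows. Statements on the series, on what has been measured and on what is new or still open speak of the compounds shown alone.

Measured so far:
Compound 1 `CC(=O)Nc1ccc(CN2CCC=C(CCC(=O)NO)C2=O)cc1` gives "not determined" (no result reported) as its entry
Compound 2 `Cc1ccc(CN2CCC=C(CCC(=O)NO)C2=O)cc1` gives 1430 nM as its value

Among the compounds with values here, in a functional assay on MDA-MB-231 cells (Homo sapiens) for inhibition, read by sulforhodamine B assay (a lower number here means a stronger inhibitor of growth, a higher number a weaker inhibitor of growth), compound 2 at 1430 nM holds the only number so far, since compound 1 has no reported result. Compound 3 `COc1ccc(CN2CCC=C(CCC(=O)NO)C2=O)cc1` differs from compound 2 by the change methoxy in place of methyl on an aromatic carbon on the shared core, methoxy in place of methyl on an aromatic carbon. Within the data shown here, no measured step is available to size such a change, so no shift beyond the usual scatter is expected in this assay in either direction. The estimate means a 1.1-fold lower number from compound 2 to compound 3 (0.04 log units; within the scatter) as the expected step. Compound 3 is expected at 1300 nM within an estimated range from 550 nM to 3000 nM in this measurement.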

Compound 3, concentration for 50% growth inhibition: 3860 nM
Beside the measured number, compound 3's estimate is 3.0-fold (0.47 log units) below it, and the stated range ends below it.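

Methoxy in place of methyl on the aromatic carbon para to a large group gives a 2.7-fold higher number from compound 2 to compound 3 (0.43 log units; beyond the scatter) in this assay. Within the data shown here, this is the first sign that this position responds to substitution, with compound 3 the weaker inhibitor of growth of the pair and the added oxygen enough to move the number beyond the scatter. No available evidence bears on the reason for this step.

With only methyl and methoxy carrying numbers at this position, two groups cannot show a trend. On these data alone, how a chlorine, a hydroxyl or an amine there would compare remains open.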